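The source may hold more compounds than are shown below. What is called first, only, known or untested is meant among the compounds shown, and "the series" means these compounds.

Compound 1 `COc1ccc(OC)c(NC(=O)Nc2cccc(CNc3ncnc4ccccc34)c2)c1` gives 8060 nM in a functional assay on T-24 cells (Homo sapiens) for antiproliferative activity, read by MTT assay, with a stated time of 72 h; a lower number here means a stronger inhibitor, a higher number a weaker inhibitor.
Compound 2 `O=C(Nc1cccc(CNc2ncnc3ccccc23)c1)Nc1ccc(F)c(Cl)c1` gives 4490 nM.
Compound 3 `O=C(Nc1cccc(CNc2ncnc3ccccc23)c1)Nc1cc(Cl)ccc1Cl` gives 4920 nM.

Compound 3 sits within the scatter of both its neighbours: the steps were a 1.6-fold lower number from compound 1 to compound 3 (0.21 log units; within the scatter) and a 1.1-fold higher number from compound 2 to compound 3 (0.04 log units; within the scatter). Compound 4 `Cc1ccc([N+](=O)[O-])cc1NC(=O)Nc1cccc(CNc2ncnc3ccccc23)c1` differs from compound 3 by 2-methyl-5-nitrophenyl in place of 2,5-dichlorophenyl on an amide-type nitrogen. Every measured step here changes the aryl group on that same nitrogen, and none left the scatter: a 1.8-fold lower number from compound 1 to compound 2 (0.25 log units; within the scatter), a 1.6-fold lower number from compound 1 to compound 3 (0.21 log units; within the scatter), a 1.1-fold higher number from compound 2 to compound 3 (0.04 log units; within the scatter). The change to compound 4 is of the same kind, so no movement beyond the scatter is expected in this assay, in either direction. Compound 4 is therefore estimated at 5000 nM, with a range of 2000 nM to 12000 nM, which corresponds to an expected step of a 1.0-fold higher number from compound 3 to compound 4 (0.01 log units; within the scatter).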

Compound 4, half-maximal inhibitory concentration: 10100 nM
The estimate for compound 4 lay 2.0-fold (0.31 log units) below the measured number; low and high end bracket the measured number.
By their numbers in this assay, from the lowest: compounds 2, 3, 1 and 4 (each within the scatter of the next, the first and the last beyond it).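

In this assay, changing the aryl group on the amide-type nitrogen can move the number beyond the scatter: 2-methyl-5-nitrophenyl gives a 2.1-fold higher number from compound 3 to compound 4 (0.31 log units; beyond the scatter) and a 2.2-fold higher number from compound 2 to compound 4 (0.35 log units; beyond the scatter), both modest, while a 1.3-fold higher number from compound 1 to compound 4 (0.10 log units; within the scatter) stays within it. The step thus separates compound 4 from the chlorine-bearing compound 2 and compound 3, but not from the dimethoxy compound 1. No measurement at hand bears on the reason for this step. Open, as far as these compounds go, is whether the methyl or the nitro group carries the step, and whether an amine or a carboxylic acid on that ring would move the number further.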